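A few compounds are considered here, and "the series" means these few. Any claim that something is new, unique, unknown or untested is made for them only; others in the source may bear on it.

Measured compounds:
Compound 1 `Cc1cc(Nc2ccn(Cc3cccc4ccccc34)n2)n2nc(SCc3ccc(Br)cc3)nc2n1` gives 3240 nM in a functional assay on MGC-803 cells (Homo sapiens) for inhibition, read by MTT assay, with a stated time of 72 h; on this read-out higher numbers stand for weaker inhibition and lower numbers for stronger inhibition.
Compound 2 `Cc1cc(Nc2cc(-c3ccccc3)[nH]n2)n2nc(SCC3CCCCC3)nc2n1` gives 12600 nM in this assay.
Compound 3 `Cc1cc(Nc2cc(-c3ccc(F)cc3)[nH]n2)n2nc(SCc3ccc(Br)cc3)nc2n1` gives 2210 nM in this assay.

Of the three, compound 2 stands at the highest number in this assay, and so shows the weakest inhibition of the set: its gap to compound 1 and its gap to compound 3 both lie beyond the usual scatter. Within the data shown here, compound 1 and compound 3 each differ from compound 2 in more than one place, so no single step between measured compounds can be read from these numbers, and nothing can be said about which of the several differences carries the gap.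

Compound 4 `CCCSc1nc2nc(C)cc(Nc3cc(-c4ccccc4)[nH]n3)n2n1` differs from compound 2 in one place only: ethyl in place of cyclohexyl on a saturated chain carbon bound to a sulfur. A six-membered saturated ring gives way to a short open chain, while the sulfur and the rest of the shared core are kept. Among the measured compounds shown here, no measured pair shows this kind of change, so its direction in this assay is not known from the data.

Compound 4 is expected at about 15000 nM, with a range from 5000 nM to 45000 nM. This estimate means a step of a 1.2-fold higher number from compound 2 to compound 4 (0.08 log units; within the scatter), which is expected to remain within the usual scatter of repeated measurements, with no clear direction.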

Compound 4, half-maximal inhibitory concentration: 12600 nM
Estimate against measurement, compound 4: 1.2-fold (0.08 log units) above; the measured number falls inside the stated range.
By their numbers in this assay, from the lowest: compounds 3 and 1 (each within the scatter of the next); then compounds 2 and 4 (each within the scatter of the next).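

Among these compounds, this is the first step in the set that can be read at a single place. In this assay, ethyl in place of cyclohexyl on a saturated chain carbon bound to a sulfur gives no change at the digits printed from compound 2 to compound 4 (within the scatter) and so leaves the read-out unmoved, although the six-membered ring of carbon only gives way to an open chain and the group becomes smaller. For this pair, then, neither the ring nor the larger group is required to hold the inhibition at the level of compound 2, though the data give no reason for this flat result.

Among the compounds shown here, since only this one exchange at this place can be read, it stays open whether the same indifference would hold for a phenyl ring, an amine, a carboxylic acid or a longer chain such as octyl on the same carbon. On these data alone, it also stays open whether the step would look alike with the 4-bromobenzyl group of compound 3 at this sulfur, or whether the change would matter in a compound with a lower number.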